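Thiazole aryl removal in the dicyanopyridine thioether series

This account rests on a few compounds, and the source may have more. Where it says the series, first, only, none or still open, it means among the compounds named here.

For the measured compounds named here, compound 2 `COc1ccc(-c2c(C#N)c(N)nc(SCc3csc(-c4ccc(I)cc4)n3)c2C#N)cc1` gives the lowest of the two numbers so far in an assay on CHO cells for displacement of a labelled ligand from adenosine receptor A1 (Homo sapiens) (on this read-out lower numbers stand for stronger inhibition and higher numbers for weaker inhibition), with 3.9 nM; its nearest neighbour is compound 1 `COc1ccc(-c2c(C#N)c(N)nc(SCc3csc(-c4ccc(Cl)cn4)n3)c2C#N)cc1`, which in this assay gives 24 nM, and the step is a 6.2-fold lower number from compound 1 to compound 2 (0.79 log units; beyond the scatter). Compound 3 `COc1ccc(-c2c(C#N)c(N)nc(SCc3cscn3)c2C#N)cc1` is the unmeasured member; the change is hydrogen in place of 4-iodophenyl on an aromatic carbon. Going by the values given here, only the step from compound 1 to compound 2 bears on it, and that step swaps one aromatic group for another rather than deleting the group altogether, so it sets no direct size for the present change. Because the 4-iodophenyl of compound 2 stands behind the strongest number 3.9 nM, its complete loss is expected to weaken binding by more than that swap did, in the direction of a higher number; the expected step is a 15-fold higher number from compound 2 to compound 3 (1.19 log units; beyond the scatter). Compound 3 is thus estimated at 60 nM, within 15 nM to 300 nM.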

Compound 3, inhibition constant: 1.3 nM
Compound 3: middle estimate off by 46-fold (1.66 log units), on the high side; the whole stated range lies above it.
By their numbers in this assay, from the lowest: compound 3; then compound 2; then compound 1.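

In this assay, the aromatic carbon next to the ring nitrogen and next to the ring sulfur needs no aromatic substituent for a low number: replacing 4-iodophenyl with hydrogen gives a 3.0-fold lower number from compound 2 to compound 3 (0.48 log units; beyond the scatter), and replacing 5-chloropyridin-2-yl with hydrogen gives an 18-fold lower number from compound 1 to compound 3 (1.27 log units; beyond the scatter). The earlier swap ranked these two aromatic groups against each other, whereas hydrogen now shows that both give higher numbers than the unsubstituted position, so the 4-iodophenyl result reflected only the better of these two groups. Nothing available explains why hydrogen gives the lowest number of the three.

On these data alone, it remains open whether a small group on this carbon, such as methyl or an amine, stays near the hydrogen result. As far as these compounds go, it is also open where unsubstituted phenyl would fall relative to the two substituted aromatic groups.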